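The source may hold more compounds than are shown below. What is called first, only, known or untested is meant among the compounds shown, and "the series" means these compounds.

Compound 1 `Cc1cc(Cc2cccc(Cl)c2)c(=O)n(CC(=O)Nc2ccc(Br)cc2)n1` was measured in an assay on HL-60 cells for agonist activity at N-formyl peptide receptor 3 (Homo sapiens), read by calcium flux; on this read-out lower numbers stand for an effect already at smaller amounts and higher numbers for an effect only at larger amounts of compound; compound 1 gives > 50000 nM, which is a limit of the assay and not a number.
Compound 2 `COc1cc(Cc2cc(C)nn(CC(=O)Nc3ccc(Br)cc3)c2=O)cc(OC)c1`; in this assay compound 2 gives > 50000 nM, again a limit of the assay.
Compound 3 `Cc1cc(Cc2cccc3ccccc23)c(=O)n(CC(=O)Nc2ccc(Br)cc2)n1`; in this assay compound 3 gives > 50000 nM, once more a limit of the assay.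

Compound 3 therefore stands where every measured compound of this small set stands: at the limit of > 50000 nM in this assay, at which 3 of the 3 values shown sit, with no number that could be compared against another. The three steps among the measured compounds, a step that the two limits leave unreadable from compound 1 to compound 2, a step that the two limits leave unreadable from compound 1 to compound 3 and a step that the two limits leave unreadable from compound 2 to compound 3, are all steps between two limits, so their size cannot be read, and they say nothing about whether one aryl group is better than another on the saturated chain carbon bound to an aromatic carbon.

The step under consideration goes from compound 3 to compound 4 `Cc1cc(Cc2ccc(C#N)cc2)c(=O)n(CC(=O)Nc2ccc(Br)cc2)n1`, and the change is 4-cyanophenyl in place of naphthalen-1-yl on a saturated chain carbon bound to an aromatic carbon. Going by the values given here, because every measured compound sits at the limit of > 50000 nM in this assay, at which 3 of the 3 values shown sit, no measured step bears on this change in a readable way. The expectation is that compound 4 also stays at the limit, so the estimated step that the limit leaves unreadable from compound 3 to compound 4 is none beyond the scatter. Compound 4 is estimated at 60000 nM, expected between 20000 nM and 200000 nM, most likely reported only as a limit in this assay.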

Compound 4, half-maximal effective concentration: > 50000 nM
Compound 4: no number, only a limit; the forecaster's own chance of this, stated with the estimate: 90%; the middle value lies beyond the limit too.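

In this assay compound 4 gives > 50000 nM, which is again a limit of the assay and not a number. The steps to compound 4 from compound 1, compound 2 and compound 3 therefore cannot be read: the limit of > 50000 nM in this assay, at which 4 of the 4 values shown sit.

The compounds shown leave open whether any aryl group on the saturated chain carbon bound to an aromatic carbon gives a measurable effect in this assay.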